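The compounds below may be only part of what the source reports. "The series", "measured", "known", "first", "only" and "open" are said of these compounds alone.

Measured compounds:
compound 1 `COC(=O)CN1C(=O)c2ccccc2NC1c1ccco1` with 380000 nM
compound 2 `COC(=O)CN1C(=O)c2ccccc2NC1c1ccc(OC)cc1` with 560000 nM
compound 3 `COC(=O)CCN1C(=O)c2ccccc2NC1c1ccccc1` with 860000 nM

All three were tested in an assay on mitochondria for inhibition of Amine oxidase [flavin-containing] B (Bos taurus), read by fluorescence, with a stated time of 60 min; a lower number here means a stronger inhibitor, a higher number a weaker inhibitor. Compound 1 has the lowest number of the three; compound 2 lies nearest to it, and a 1.5-fold higher number from compound 1 to compound 2 (0.17 log units; within the scatter) is within the scatter, so the two cannot be ordered. Among the measured compounds shown here, compound 3 is furthest, with a number beyond the scatter above compound 1; it differs from compound 1 both in the aryl group on the saturated ring carbon and in the length of the ester-bearing chain, so no single step is known for it.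

Compound 4 `COC(=O)CCCN1C(=O)c2ccccc2NC1c1ccco1` is not yet measured. It keeps the furan-2-yl of compound 1 and changes the chain: 2-(methoxycarbonyl)ethyl in place of methoxycarbonyl on a saturated chain carbon bound to an amide-type nitrogen in a ring. For the measured compounds named here, no measured step in this assay concerns the chain alone; the only step known, from compound 1 to compound 2, changes the aryl group and is within the scatter. What compound 1 and compound 3 show together is that a longer chain has so far gone with a higher number, but this is confounded by the aryl change.

For compound 4, a modest rise in the number is therefore expected, a 1.6-fold higher number from compound 1 to compound 4 (0.20 log units; within the scatter), with wide uncertainty. The estimate for compound 4 is 600000 nM, with a range from 250000 nM to 1500000 nM.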

Compound 4, half-maximal inhibitory concentration: 780000 nM
For compound 4 the middle estimate is 1.3-fold (0.11 log units) below the measured one; the range from low to high includes it.
By their numbers in this assay, from the lowest: compounds 1, 2, 4 and 3 (each within the scatter of the next, the first and the last beyond it).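

Among the compounds shown here, with the furan-2-yl held fixed, the chain change alone leads in this assay to a 2.1-fold higher number from compound 1 to compound 4 (0.31 log units; beyond the scatter) and is the first single change in these compounds to pass the scatter, whereas the aryl change between compound 1 and compound 2 stayed within it. Compound 3 had left the chain mixed with a change of aryl group, but here the effect of 2-(methoxycarbonyl)ethyl in place of methoxycarbonyl, on a saturated chain carbon bound to an amide-type nitrogen in a ring, can be read on its own. The two groups have the same oxygen count and the same counts of hydrogen-bond donors and acceptors, and no measurement at hand bears on why the number moves with this change.

Going by these compounds, it remains open whether the number keeps climbing with a still longer chain or whether the same chain change would give a similar step with 4-methoxyphenyl in place of furan-2-yl. On these data alone, it is also open whether the methyl ester at the chain end matters, a question that a carboxylic acid or an amine at that end would address.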